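The compounds below may be only part of what the source reports. "The series", "measured", "known", "first", "only" and "open" are said of these compounds alone.

Measured compounds:
Compound 1 `N=c1c2c(-c3ccccc3)c(-c3ccccc3)n(CC3CC3)c2ncn1CC1CCOCC1` — in an ADME assay for permeability, using PAMPA, with a stated time of 30 min, at pH 7.4 (on this read-out lower numbers stand for lower permeability and higher numbers for higher permeability), compound 1 gives > 1000 10^-6 cm/s, which is a limit of the assay and not a number.
Compound 2 `COc1ccc(Cn2c(-c3ccccc3)c(-c3ccccc3)c3c(=N)n(CC4CCOCC4)cnc32)cc1` — in this assay compound 2 gives 1270 10^-6 cm/s.
Compound 3 `N=c1c2c(-c3ccccc3)cn(Cc3ccccc3)c2ncn1CCO` — in this assay compound 3 gives 1270 10^-6 cm/s.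

On these numbers compound 2 stands level with compound 3 at the digits shown, within the scatter. Among the compounds with values here, the one measured step, a step that the limit leaves unreadable from compound 1 to compound 2, cannot be sized because of the limit of > 1000 10^-6 cm/s in this assay, at which 1 of the 3 values shown sits. Compound 4 `COc1ccc(Cn2c(-c3ccccc3)c(-c3ccccc3)c3c(=N)n(CCO)cnc32)cc1` has not yet been measured. It differs from compound 2 in one place: hydroxymethyl in place of oxan-4-yl on a saturated chain carbon bound to an aromatic nitrogen. Read one bond further out, the same difference is (oxan-4-yl)methyl to 2-hydroxyethyl. Within the data shown here, no measured step covers this change. Compound 3 carries a 2-hydroxyethyl chain on a saturated chain carbon bound to an aromatic nitrogen, but it differs from compound 2 elsewhere as well, so its value shows only that such a chain sits at the same reading as compound 2. The step from compound 2 to compound 4 is therefore expected to be a 1.1-fold lower number from compound 2 to compound 4 (0.02 log units; within the scatter), nothing beyond the scatter. Compound 4 is estimated at 1200 10^-6 cm/s, in a range from 550 10^-6 cm/s to 2200 10^-6 cm/s.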

Compound 4, apparent permeability: > 1000 10^-6 cm/s
Compound 4: no number, only a limit (the forecaster's own chance of this, stated with the estimate: 30%); the middle value does not contradict the limit.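

In this assay compound 4 gives > 1000 10^-6 cm/s, which is a limit and not a number. Within the data shown here, no step can therefore be read between compound 2 and compound 4: the limit of > 1000 10^-6 cm/s in this assay, at which 2 of the 4 values shown sit. The compounds shown leave open whether 2-hydroxyethyl in place of (oxan-4-yl)methyl changes the reading at all.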